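Notes on compound 2 and the step to compound 4

The source may report more compounds than this note shows. Statements on the series, on what has been measured and on what is new or still open speak of the compounds shown alone.

In an assay for inhibition of liver carboxylesterase 1 (Homo sapiens), read by spectrophotometry (a lower number here means a stronger inhibitor, a higher number a weaker inhibitor), compound 1, `CCOc1ccc(NS(=O)(=O)c2ccc(Cl)cc2)cc1`, reports only the limit > 100000 nM. Compound 2, `Cc1ccc(S(=O)(=O)Nc2ccc(NS(=O)(=O)c3ccc(F)cc3)cc2)cc1`, in this assay also gives only the limit > 100000 nM. Compound 3, `O=C(O)c1ccc(S(=O)(=O)Nc2ccc(NS(=O)(=O)c3ccc(F)cc3)cc2)cc1`, in this assay likewise stays at the limit > 100000 nM. Among the compounds with values here, the single step that can be drawn, a step that the two limits leave unreadable from compound 2 to compound 3, therefore has no readable size; the same holds for whatever separates compound 1 from compound 2 or from compound 3, where both values are limits. Compound 2 thus has no position on a scale: its own value is a limit, and the two other values in the series are limits as well, as summed up by the limit of > 100000 nM in this assay, at which 3 of the 3 values shown sit.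

Compound 4, `Cc1ccc(S(=O)(=O)Nc2ccc(NS(=O)(=O)c3ccc(F)c(F)c3)cc2)cc1`, differs from compound 2 by fluoro in place of hydrogen on an aromatic carbon. Within the data shown here, no measured step bears on this change with a readable size, since the only step drawn, from compound 2 to compound 3, lies between two limits. Among the measured compounds shown here, with no number anywhere, no direction and no size of step in this assay beyond the scatter can be expected for compound 4; the expectation is that compound 4 also sits at the limit, with a step that the limit leaves unreadable from compound 2 to compound 4 as the estimated step. Compound 4 is accordingly estimated at 200000 nM, from 50000 nM to 1000000 nM.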

Compound 4, inhibition constant: > 100000 nM
Compound 4 was reported as a limit; the forecaster's own chance of this, stated with the estimate: 85%; the middle value is on the limit's open side.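

No new step can be read from compound 2 to compound 4, as both values are limits and the whole series stays at one limit: the limit of > 100000 nM in this assay, at which 4 of the 4 values shown sit.

The compounds shown leave open whether fluoro in place of hydrogen on this ring changes inhibition at all, and which change to the shared core would give a readable inhibition constant in this assay.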